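Shortening a chain on compound 3

A few compounds are considered here, and "the series" means these few. Any claim that something is new, unique, unknown or untested is made for them only; others in the source may bear on it.

Results so far in a functional assay on the whole organism with Homo sapiens as the target (a lower number here means a stronger inhibitor, a higher number a weaker inhibitor), for three compounds
Compound 1 `COc1ccc(CCCCCCCCOc2ccc(C[S+]([O-])c3cccc(C(=O)O)c3)nc2/C=C/C(=O)O)cc1` gives 3200 nM
Compound 2 `COc1ccc(CCCCCCCCOc2ccc(CSCc3cccc(C(=O)O)c3)nc2/C=C/C(=O)O)cc1` gives 271 nM
Compound 3 `COc1ccc(CCCCCCCCOc2ccc(CSCc3cccc(C(=O)O)c3)nc2CCC(=O)O)cc1` gives 190 nM

Compound 3 sits level with compound 2 within the scatter, and both lie well under compound 1. The next compound, compound 4 `COc1ccc(CCCCOc2ccc(CSCc3cccc(C(=O)O)c3)nc2CCC(=O)O)cc1`, differs from compound 3 in one place (4-methoxyphenyl in place of 4-(4-methoxyphenyl)butyl on a saturated chain carbon, four bonds along the chain from an oxygen on an aromatic ring). It has 4-methoxyphenyl in place of 4-(4-methoxyphenyl)butyl on a saturated chain carbon, four bonds along the chain from an oxygen on an aromatic ring.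

Neither measured step touches this chain, so neither gives a direct measure of the change. A change on a saturated chain carbon bound to an aromatic carbon brought a 12-fold lower number from compound 1 to compound 2 (1.07 log units; beyond the scatter) and counts as large. Putting 2-carboxyethyl in place of 2-carboxyethenyl brought a 1.4-fold lower number from compound 2 to compound 3 (0.15 log units; within the scatter) and stays within the scatter. The first of these shows only that a single edit in this series can move the number a long way. A clear rise beyond the scatter is therefore expected in this assay, meaning a weaker inhibitor, though with wide uncertainty. The estimated change is a 7.9-fold higher number from compound 3 to compound 4 (0.90 log units; beyond the scatter) (an expectation only). Compound 4 is expected at 1500 nM (estimated range 400 nM to 6000 nM).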

Compound 4, half-maximal inhibitory concentration: 3800 nM
For compound 4 the middle estimate is 2.5-fold (0.40 log units) below the measured one; measured number inside the range.
By their numbers in this assay, from the lowest: compounds 3 and 2 (each within the scatter of the next); then compounds 1 and 4 (each within the scatter of the next).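

In this assay, putting 4-methoxyphenyl in place of 4-(4-methoxyphenyl)butyl on a saturated chain carbon, four bonds along the chain from an oxygen on an aromatic ring, gives a 20-fold higher number from compound 3 to compound 4 (1.30 log units; beyond the scatter), which means a much weaker inhibitor. Within the data shown here, this is the first direct reading on this chain, since the earlier steps changed other parts of the molecule; the methoxy-bearing aromatic ring stays and the group shrinks from 12 heavy atoms to 8, so the length of the chain counts strongly between these two compounds. The data offered here contain no measurement that explains why the shorter chain gives so much weaker an inhibitor.

With only two chain lengths shown, it remains open whether the number climbs steadily or abruptly as the chain shortens, and whether a longer chain would bring it lower still. Going by these compounds, it also remains open how much the methoxy group of the 4-methoxyphenyl contributes at either chain length, a question that a chlorine or a hydroxyl group in its place could address.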